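The source may hold more compounds than are shown below. What is called first, only, known or untested is meant among the compounds shown, and "the series" means these compounds.

Measured so far in a physicochemical assay for lipophilicity; on this read-out lower numbers stand for lower lipophilicity and higher numbers for higher lipophilicity:
- Compound 1 `C=C[C@@H]1C[C@]1(NC(=O)[C@@H]1[C@H](CC)[C@@H]2CN1C(=O)[C@H](C(C)(C)C)NC(=O)O[C@@H]1C[C@H]1CCCCCc1nc3ccc(OC)cc3nc1O2)C(=O)NS(=O)(=O)C1CC1`: 4.1
- Compound 2 `CC[C@@H]1[C@@H]2CN(C(=O)[C@H](C(C)(C)C)NC(=O)O[C@@H]3C[C@H]3CCCCCc3nc4ccc(OC)cc4nc3O2)[C@@H]1C(=O)N[C@]1(C(=O)NS(=O)(=O)C2CC2)C[C@H]1CC`: 4.6

Of these two compounds, compound 2 stands higher at 4.6, and the gap to compound 1 lies beyond the scatter of the measurement. The next compound to be measured, compound 3 `CC[C@@H]1[C@@H]2CN(C(=O)[C@H](C(C)(C)C)NC(=O)O[C@@H]3C[C@H]3CCCCCc3nc4ccc(OC)cc4nc3O2)[C@@H]1C(=O)N[C@]1(C(=O)NS(=O)(=O)C2CC2)C[C@H]1C(F)F`, keeps the shared core of compound 2 and changes one group. It carries difluoromethyl in place of ethyl on a saturated ring carbon. That carbon belongs to a three-membered non-aromatic ring of carbon only.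

Among the compounds with values here, only one measured step bears on this swap: a number 0.50 log units higher from compound 1 to compound 2 (beyond the scatter), where ethyl took the place of vinyl on a saturated ring carbon. That step was modest, and it gives a rough idea of how far one small group can move the number in this assay. Within the data shown here, no measured compound carries difluoromethyl, so the direction here is a judgement and not a trend in the data. A downward move of similar size is expected, and the estimated change is a number 0.50 log units lower from compound 2 to compound 3 (beyond the scatter). For compound 3 the expected value is 4.1, with an estimated range from 3.6 to 4.6.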

Compound 3, distribution coefficient: 3.5
Beside the measured number, compound 3's estimate is 0.60 log units above it; the measured number lies below the stated range.
By their numbers in this assay, from the lowest: compound 3; then compound 1; then compound 2.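

On the saturated ring carbon of the three-membered non-aromatic ring of carbon only, the swap to difluoromethyl produces the largest change so far in this assay (a number 1.10 log units lower from compound 2 to compound 3 (beyond the scatter)), showing that this position can shift the number well beyond what the earlier vinyl-to-ethyl step (a number 0.50 log units higher from compound 1 to compound 2 (beyond the scatter)) revealed. Difluoromethyl also stands apart from vinyl (a number 0.60 log units lower from compound 1 to compound 3 (beyond the scatter)), so the three groups run from difluoromethyl at the lowest number through vinyl to ethyl at the highest, and the count of heavy atoms does not set this order, since difluoromethyl has more heavy atoms than ethyl yet gives the lower number. No measurement offered here explains why these groups fall in this order.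

On these data alone, it remains open where a fluoromethyl or trifluoromethyl group would fall on this order, and whether a longer chain such as propyl would rise above ethyl. These three compounds also cannot tell whether the same swap would give a change of similar size on a different core.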